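The source may hold more compounds than are shown below. What is called first, only, known or untested is meant among the compounds shown, and "the series" means these compounds.

In an ADME assay (liver) for pharmacokinetics, with Liver microsome (Rattus norvegicus) as the target, read by LC-MS, using microsomes, tested at 2 uM (on this read-out lower numbers stand for slow clearance and higher numbers for fast clearance), compound 1 `O=C(N[C@@H]1CCCC[C@H]1O)c1cnc(Oc2ccccc2)c(-c2ccc(Cl)cc2)c1` gives 0.353 mL/min/kg, compound 2 `O=C(N[C@@H]1CCCC[C@H]1O)c1cnc(OCc2ccccc2)c(-c2ccc(Cl)cc2)c1` gives 0.02 mL/min/kg and compound 3 `O=C(N[C@@H]1CCCC[C@H]1O)c1cnc(OCc2ncccn2)c(-c2ccc(Cl)cc2)c1` gives 0.012 mL/min/kg. Compound 3 thus sits level with compound 2 at the low end of the series, well away from compound 1. Compound 4 `O=C(N[C@@H]1CCCC[C@H]1O)c1cnc(OCc2ccccn2)c(-c2ccc(Cl)cc2)c1` carries pyridin-2-yl in place of pyrimidin-2-yl on a saturated chain carbon bound to an oxygen on an aromatic ring. Within the data shown here, the closest precedent is a 1.7-fold lower number from compound 2 to compound 3 (0.22 log units; within the scatter), a change at that same place that stays within the scatter. The large steps, an 18-fold lower number from compound 1 to compound 2 (1.25 log units; beyond the scatter) and a 29-fold lower number from compound 1 to compound 3 (1.47 log units; beyond the scatter), replace phenyl on the oxygen and are a different kind of change. No step beyond the scatter is therefore expected in this assay. The expected step is a 1.3-fold higher number from compound 3 to compound 4 (0.12 log units; within the scatter). Compound 4 is estimated at 0.016 mL/min/kg, within a range of 0.007 mL/min/kg to 0.04 mL/min/kg.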

Compound 4, clearance: 0.044 mL/min/kg
The estimate for compound 4 lay 2.8-fold (0.44 log units) below the measured number; the whole stated range lies below it.
By their numbers in this assay, from the lowest: compounds 3 and 2 (each within the scatter of the next); then compound 4; then compound 1.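

In this assay, the ring on the saturated chain carbon is not interchangeable: a 3.7-fold higher number from compound 3 to compound 4 (0.56 log units; beyond the scatter) and a 2.2-fold higher number from compound 2 to compound 4 (0.34 log units; beyond the scatter) both lie beyond the scatter, although phenyl and pyrimidin-2-yl lie within it of each other. Pyridin-2-yl therefore separates from both groups at this place. The (pyridin-2-yl)methyl group still gives a lower number than phenyl on the oxygen, with an 8.0-fold lower number from compound 1 to compound 4 (0.90 log units; beyond the scatter) as the step.

Nothing available explains the higher number with pyridin-2-yl.

Open, as far as these compounds go, is how pyridin-3-yl or a saturated cyclohexyl ring at this place would read out in this assay on the same core.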